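Swapping the aryl group on the core of compound 1

The source may hold more compounds than are shown below. What is called first, only, known or untested is meant among the compounds shown, and "the series" means these compounds.

Compound 1 `O=C(NO)c1ccc(NCc2nc(-c3cccc4cnccc34)nn2-c2ccccc2)cc1` is a hydroxamic acid tested in an assay on Sf9 cells for inhibition of protein deacetylase HDAC6 (Homo sapiens), read by fluorescence, with a stated time of 40 min, tested at 100 nM (a lower number here means less inhibition, a higher number more inhibition at the concentration tested (going by the name of the read-out)), where compound 1 gives 40.2%. This is the lowest of the three numbers recorded: compound 2 `Cc1ccc(-n2nc(-c3ccccc3)nc2CNc2ccc(C(=O)NO)cc2)cc1` gives 60.7% and compound 3 `CC(C)c1ccc(-n2nc(-c3ccccc3)nc2CNc2ccc(C(=O)NO)cc2)cc1` gives 52.6%, both beyond the scatter above compound 1. For the measured compounds named here, the only measured step, a number 8.1 percentage points lower from compound 2 to compound 3 (within the scatter), changes a group elsewhere on the core and lies within the scatter, so it does not bear directly on the change to compound 4 `CC(C)c1ccc(-c2nc(CNc3ccc(C(=O)NO)cc3)n(-c3ccccc3)n2)cc1`, which is 4-isopropylphenyl in place of isoquinolin-5-yl on an aromatic carbon. Compounds 2 and 3, which carry a phenyl at that carbon, sit higher than compound 1, so a modest rise is expected, giving a number 9.8 percentage points higher from compound 1 to compound 4 (within the scatter). The estimate for compound 4 is 50%, ranging from 30% to 70%.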

Compound 4, a percentage reported as inhibition, at one concentration (the size of the read-out at that concentration, not a potency): 27.6%
For compound 4 the middle estimate is 22.4 percentage points above the measured one; measured number outside the range, below it.
By their numbers in this assay, from the lowest: compound 4; then compound 1; then compounds 3 and 2 (each within the scatter of the next).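

In this assay, putting 4-isopropylphenyl in place of isoquinolin-5-yl on this aromatic carbon gives a number 12.6 percentage points lower from compound 1 to compound 4 (beyond the scatter), which shows that the number responds to the group at this position. The change removes the one hydrogen-bond acceptor counted in the leaving group as well as one of its two rings, and this single pair cannot separate those two differences. Nothing available explains the drop. Still open, as far as these compounds go, is how a carboxylic acid or an amine at this carbon would compare with isoquinolin-5-yl.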